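From 4-(trifluoromethoxy)phenoxy to chloro in the series

A few compounds are considered here, and "the series" means these few. Any claim that something is new, unique, unknown or untested is made for them only; others in the source may bear on it.

Measured so far in an ADME assay on J774 cells (Mus musculus) for antiproliferative activity, with a stated time of 72 h (a higher number here means that more compound is needed for the effect, a lower number that less compound is needed), for three compounds:
Compound 1 `CCCCc1cc2c(=O)cc(C)[nH]c2cc1OCCOc1ccccc1` gives 28000 nM as its value
Compound 2 `CCCCc1cc2c(=O)c(-c3ccc(OC(F)(F)F)cc3)c(C)[nH]c2cc1OCCOc1ccccc1` gives 20000 nM as its value
Compound 3 `CCCCc1cc2c(=O)c(-c3ccc(Oc4ccc(OC(F)(F)F)cc4)cc3C)c(C)[nH]c2cc1OCCOc1ccccc1` gives 16000 nM as its value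

The value of compound 3 lies within the scatter of those of compound 1 and compound 2, so these numbers do not separate the three. Compound 4 `CCCCc1cc2c(=O)c(-c3ccc(Cl)cc3C)c(C)[nH]c2cc1OCCOc1ccccc1` carries chloro in place of 4-(trifluoromethoxy)phenoxy on an aromatic carbon and otherwise matches compound 3. For the measured compounds named here, the only measured step with a bearing on this is a 1.4-fold lower number from compound 1 to compound 2 (0.15 log units; within the scatter) for 4-(trifluoromethoxy)phenyl in place of hydrogen on an aromatic carbon, and it stays within the scatter. Going by the values given here, no measured step removes the group that leaves here, so the support is indirect. No step beyond the scatter is therefore expected in this assay for this change. The expected step is a 1.1-fold higher number from compound 3 to compound 4 (0.05 log units; within the scatter) on these numbers. Compound 4 is estimated at 18000 nM with an expected range from 9000 nM to 35000 nM in this assay.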

Compound 4, half-maximal effective concentration: > 21000 nM
Compound 4: a limit, no number; the forecaster's own chance of this, stated with the estimate: 10%; middle value at least 1.1-fold (0.06 log units) away from the limit.
By their numbers in this assay, from the lowest: compounds 3, 2 and 1 (each within the scatter of the next).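

In this assay compound 4 gives > 21000 nM, which is a limit of the assay and not a number. For the compounds shown here, this is the first measured removal of 4-(trifluoromethoxy)phenoxy from this aromatic carbon, and the floors of an at least 1.3-fold higher number from compound 3 to compound 4 (0.11 log units; that floor lies within the scatter) and an at least 1.0-fold higher number from compound 2 to compound 4 (0.02 log units; that floor lies within the scatter) both lie within the scatter, so neither step's full size is known. The step from compound 1 to compound 4 cannot be read. Still open, on these data alone, is the actual size of these steps, and whether an amine or a carboxylic acid in place of chloro on this aromatic carbon would give a step beyond the scatter.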